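From isopropyl to sec-butyl: a half-life estimate

This account rests on a few compounds, and the source may have more. Where it says the series, first, only, none or still open, it means among the compounds named here.

Values measured in an in vivo ADME assay on the whole organism (strain Sprague-Dawley) for metabolic stability, with Rattus norvegicus as the target (a higher number here means that the compound lasts longer, a lower number that the compound disappears faster), so far:
Compound 1 `CC(C)[C@@H]1NC[C@@H](C)Oc2ccccc2CCCNC(=O)[C@@H](Cc2ccc(F)cc2)NC(=O)[C@@H](C)N(C)C1=O` gives 34 h
Compound 2 `C[C@@H]1C(=O)N[C@H](Cc2ccc(F)cc2)C(=O)NCCCc2ccc(F)cc2OCCN[C@@H](C2CC2)C(=O)N1C` gives 44 h
Compound 3 `C[C@@H]1C(=O)N[C@H](Cc2ccc(F)cc2)C(=O)NCCCc2ccccc2OCCN[C@@H](C2CC2)C(=O)N1C` gives 14 h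

Compound 1 and compound 2 lie within the usual scatter of each other, and compound 3 stands below compound 1 by more than that scatter. Compound 1 therefore sits with the higher pair of the three numbers.

The next compound is compound 4 `CC[C@H](C)[C@@H]1NC[C@@H](C)Oc2ccccc2CCCNC(=O)[C@@H](Cc2ccc(F)cc2)NC(=O)[C@@H](C)N(C)C1=O`, and the difference from compound 1 is methyl in place of hydrogen on a saturated chain carbon, two bonds along the chain from a saturated ring carbon. It is methyl in place of hydrogen on a saturated chain carbon, two bonds along the chain from a saturated ring carbon, so isopropyl becomes sec-butyl.

Going by the values given here, only one measured step changes a single place, a 3.1-fold lower number from compound 2 to compound 3 (0.50 log units; beyond the scatter), and it concerns hydrogen in place of fluoro on an aromatic carbon. Among the compounds with values here, it bears only loosely on this change, since no measured step adds a methyl on this chain. It does show that a change in one place can pass the scatter, so the range here is kept wide. No direction is favoured by the data, and no step beyond the scatter is expected in this assay.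

The expected change is no change at the digits printed from compound 1 to compound 4 (within the scatter). For compound 4 the estimated half-life is 34 h, with an expected range from 16 h to 70 h.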

Compound 4, half-life: 44 h
Compound 4: the middle estimate sits 1.3-fold (0.11 log units) below what was measured; the range from low to high includes it.
By their numbers in this assay, from the lowest: compound 3; then compounds 1, 2 and 4 (each within the scatter of the next).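

In this assay, the move from isopropyl to sec-butyl gives a 1.3-fold higher number from compound 1 to compound 4 (0.11 log units; within the scatter), so this methyl, on a saturated chain carbon, two bonds along the chain from a saturated ring carbon, leaves the half-life within the scatter. Going by these compounds alone, this is the first measured step at this position. Within the data shown here, the only earlier single-place step, a 3.1-fold lower number from compound 2 to compound 3 (0.50 log units; beyond the scatter), concerned fluoro on an aromatic carbon and passed the scatter, whereas this change on the core of compound 1 does not, so a single-place change need not pass the scatter. Nothing measured here accounts for this result.

On these data alone, one step at this position cannot show how far the outcome extends, and whether a longer chain, an amine or a carboxylic acid in place of the sec-butyl would also stay within the scatter remains open. As far as these compounds go, it is also open whether fluoro on the aromatic carbon, the difference between compound 2 and compound 3, would give a step of similar size on compound 4.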